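A few compounds are considered here, and "the series" means these few. Any claim that something is new, unique, unknown or untested is made for them only; others in the source may bear on it.

Measured compounds and their values:
- Compound 1 `Cc1nc(-c2ccccc2NCC2=NCCN2)co1`: 324 nM
- Compound 2 `c1ccc(-c2cnoc2)c(NCC2=NCCN2)c1`: 45.7 nM
- Compound 3 `Cc1ccsc1-c1ccccc1NCC1=NCCN1`: 0.851 nM

All three were tested in a functional assay for activation of Alpha-1A adrenergic receptor (Homo sapiens), read by calcium flux; on this read-out lower numbers stand for an effect already at smaller amounts and higher numbers for an effect only at larger amounts of compound. Compound 3 stands lowest of the three numbers: the step of a 54-fold lower number from compound 2 to compound 3 (1.73 log units; beyond the scatter) is large, and the step of a 380-fold lower number from compound 1 to compound 3 (2.58 log units; beyond the scatter) is larger still. Both steps show the same thing: replacing a five-membered ring with several hetero atoms by the 3-methylthiophen-2-yl group lowers the number strongly.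

Compound 4 `Cc1noc(-c2ccccc2NCC2=NCCN2)n1` reverses that direction. Its change is 3-methyl-1,2,4-oxadiazol-5-yl in place of 3-methylthiophen-2-yl on an aromatic carbon. The entering ring carries more hetero atoms than either ring in compound 1 or compound 2, both of which gave much higher numbers than compound 3. Among the measured compounds shown here, no measured pair covers this exact ring, so the expectation rests on the pattern seen in the steps from compound 1 and compound 2 to compound 3. For compound 4 a large increase is expected, a 590-fold higher number from compound 3 to compound 4 (2.77 log units; beyond the scatter), most likely landing near or beyond the number of compound 1. The estimate for compound 4 in this assay is 500 nM, with a range from 100 nM to 3000 nM.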

Compound 4, half-maximal effective concentration: 661 nM
Estimate against measurement, compound 4: 1.3-fold (0.12 log units) below, and the stated range covers the measured number.
By their numbers in this assay, from the lowest: compound 3; then compound 2; then compound 1; then compound 4.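

In this assay, the 3-methylthiophen-2-yl and 3-methyl-1,2,4-oxadiazol-5-yl groups both have 6 heavy atoms, yet swapping them gives a 780-fold higher number from compound 3 to compound 4 (2.89 log units; beyond the scatter) as the result. At this position, then, a very large change occurs without any change in heavy-atom count, while the ring goes from 1 hetero atom to 3 hetero atoms and from 1 hydrogen-bond acceptor to 3. The new ring also gives a 14-fold higher number from compound 2 to compound 4 (1.16 log units; beyond the scatter) and only a 2.0-fold higher number from compound 1 to compound 4 (0.31 log units; beyond the scatter) as its smallest step, just beyond the usual scatter, so compound 4 has the highest number of the four.

No measurement at hand explains these differences. Going by these compounds, it remains open how a plain phenyl ring or a thiophen-2-yl ring without its methyl group would behave at this position.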